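A few compounds are considered here, and "the series" means these few. Any claim that something is new, unique, unknown or untested is made for them only; others in the source may bear on it.

Of the compounds shown here, three sharing one core have been measured in a physicochemical assay for solubility, at pH 7.4; on this read-out lower numbers stand for lower solubility and higher numbers for higher solubility. Compound 1 `Cc1nc(C)n(-c2nc(-c3ccccc3)cc(=O)[nH]2)n1` gives 130000 nM in this assay. Compound 2 `Cc1cc(-c2ccccc2)n(-c2nc(C(F)(F)F)cc(=O)[nH]2)n1` gives 200000 nM in this assay, and compound 3 `Cc1cc(Nc2ccc(C(=O)N(C)C)cc2)n(-c2nc(C(F)(F)F)cc(=O)[nH]2)n1` gives 200000 nM in this assay. On these numbers compound 2 stands level with compound 3 at the digits shown, and the two together are the highest of the three; the gap from compound 2 to compound 1, a lower number, lies within the usual scatter of repeated measurements, so no real difference between any pair is established.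

Compound 4 `Cc1cc(Nc2ccccn2)n(-c2nc(C(F)(F)F)cc(=O)[nH]2)n1` has not yet been measured in this assay. It differs from compound 2 in one place: (pyridin-2-yl)amino in place of phenyl on an aromatic carbon. Within the data shown here, no step between measured compounds matches this change, so the expectation rests on the neighbours alone. Compound 3, which also carries an amino-linked aromatic group at this position, sits at the same reading as compound 2, and this points to no movement beyond the scatter.

The expected step from compound 2 to compound 4 is therefore no change at the digits printed from compound 2 to compound 4 (within the scatter), that is, none beyond the scatter. Compound 4 is estimated at 200000 nM in this assay, with a range from 100000 nM to 300000 nM.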

Compound 4, solubility: 25000 nM
For compound 4 the middle estimate is 8.0-fold (0.90 log units) above the measured one; the whole stated range lies above it.
By their numbers in this assay, from the lowest: compound 4; then compounds 1, 2 and 3 (each within the scatter of the next).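

Among these compounds, replacing phenyl with (pyridin-2-yl)amino on this aromatic carbon gives an 8.0-fold lower number from compound 2 to compound 4 (0.90 log units; beyond the scatter) in this assay, the only step beyond the scatter seen so far, so a change at this position can move the number clearly. An amino link here does not settle the reading by itself: compound 3, which also has an amino-linked aromatic group at this position, gives 200000 nM, whereas compound 4 gives 25000 nM, so the two differ in what is attached to that link. Nothing measured here bears on what lies behind the step.

As far as these compounds go, it remains open whether the lower number goes with the amino link or with the ring nitrogen of the pyridine; a plain phenylamino group and a pyridin-2-yl group joined directly to this carbon would separate the two. This single step also leaves open whether the same change would move the number as far with another group, such as a methyl, in place of the trifluoromethyl.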